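This account rests on a few compounds, and the source may have more. Where it says the series, first, only, none or still open, it means among the compounds named here.

Of the compounds shown here, three built on one shared core have been measured in a functional assay on MCF7 cells (Homo sapiens) for antiproliferative activity, read by MTT assay, with a stated time of 48 h; on this read-out higher numbers stand for weaker inhibition and lower numbers for stronger inhibition. Compound 1, `COc1ccc(-n2nncc2CN2C(=O)C3(C(C#N)=C(N)Oc4c3c3nc5ccccc5nc3c3ccccc43)c3ccccc32)cc1`, gives only a limit in this assay, > 50000 nM, and not a number. Compound 2, `N#CC1=C(N)Oc2c(c3nc4ccccc4nc3c3ccccc23)C12C(=O)N(Cc1cnnn1-c1cccc(S(N)(=O)=O)c1)c1ccccc12`, gives 42500 nM. Going by the values given here, the one measured step, an at least 1.1-fold lower number from compound 1 to compound 2 (0.07 log units; that floor lies within the scatter), swaps one group on an aromatic nitrogen for another, and its floor lies within the scatter. Compound 3, `CCc1ccccc1-n1nncc1CN1C(=O)C2(C(C#N)=C(N)Oc3c(N)cc4nc5ccccc5nc4c32)c2ccccc21`, gives 24600 nM in this assay. Its number sits close to that of compound 2, a gap within the scatter, so the two cannot be told apart. Compound 1 alone stands at the limit of > 50000 nM in this assay, at which 1 of the 3 values shown sits.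

The next compound, compound 4, `CCc1cccc(CC)c1-n1nncc1CN1C(=O)C2(C(C#N)=C(N)Oc3c(N)cc4nc5ccccc5nc4c32)c2ccccc21`, differs from compound 3 in a single place: ethyl in place of hydrogen on an aromatic carbon. Among the compounds with values here, no measured step touches this part of the molecule. The step of an at least 1.1-fold lower number from compound 1 to compound 2 (0.07 log units; that floor lies within the scatter) concerns a different group, on a nitrogen rather than a carbon, and starts from a limit, so it gives no guide to the size or direction of the present change. With nothing pointing either way, no step beyond the scatter is expected in this assay, and the step of a 1.1-fold lower number from compound 3 to compound 4 (0.05 log units; within the scatter) is expected to be small. Compound 4 is therefore estimated at 22000 nM, with a range from 8000 nM to 60000 nM.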

Compound 4, half-maximal inhibitory concentration: > 50000 nM
Compound 4: only a limit was reported (the forecaster's own chance of this, stated with the estimate: 25%); middle value at least 2.2-fold (0.35 log units) from the limit.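

In this assay, going by these compounds alone, the change from 2-ethylphenyl to 2,6-diethylphenyl gives the first step at this position on an aromatic carbon, an at least 2.0-fold higher number from compound 3 to compound 4 (0.30 log units; that floor lies within the scatter). The direction is toward weaker inhibition, so adding the second ethyl group brought no measurable gain, but only a floor is known for this step and that floor alone does not clear the usual spread of repeated measurements, so the true size of the loss could be small or much larger. Compound 4 now reads as a limit and not a number, and it shares that limit with one earlier compound: the limit of > 50000 nM in this assay, at which 2 of the 4 values shown sit.

The compounds shown leave open how a smaller or different group in this same place, such as a methyl, a chlorine or an amine, would read, and so whether any group there can be tolerated or only ethyl falls short. They also leave open whether 2-ethylphenyl and 2,6-diethylphenyl would differ in the same direction on the core of compound 1, which carries no amine on its fused rings.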